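The source may report more compounds than this note shows. Statements on the series, on what has been measured and on what is new or still open speak of the compounds shown alone.

Working notes on the series. In a functional assay on HT-29 cells (Homo sapiens) for cytotoxicity, read by sulforhodamine B assay, with a stated time of 2 days, tested at 100 uM (a lower number here means less inhibition, a higher number more inhibition at the concentration tested (going by the name of the read-out)), compound 1 `O=C(Nn1c(-c2cccc([N+](=O)[O-])c2)nc2c(-c3ccc(Cl)cc3)n[nH]c2c1=O)c1cccnc1` gives 15.1%. Compound 2 `O=C(Nn1c(-c2cccc([N+](=O)[O-])c2)nc2c(-c3ccc(F)cc3)n[nH]c2c1=O)c1cccnc1` gives 24.7% in this assay. Compound 3 `O=C(Nn1c(-c2cccc([N+](=O)[O-])c2)nc2c(-c3cccs3)n[nH]c2c1=O)c1cccnc1` gives 3.9% in this assay, the lowest of the three numbers; compound 1 is its nearest neighbour, and a number 11.2 percentage points lower from compound 1 to compound 3 (beyond the scatter), while a number 20.8 percentage points lower from compound 2 to compound 3 (beyond the scatter). The change between compound 1 and compound 2 is of a different kind, and a number 9.6 percentage points higher from compound 1 to compound 2 (within the scatter).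

Compound 4 `O=C(Nn1c(-c2cccc([N+](=O)[O-])c2)nc2c(CCc3ccccc3)n[nH]c2c1=O)c1cccnc1` differs from compound 3 at the same place that the two larger measured steps touched: phenethyl in place of thiophen-2-yl on an aromatic carbon. Among the compounds with values here, both of those steps put thiophen-2-yl in place of 4-chlorophenyl or 4-fluorophenyl and lowered inhibition; leaving thiophen-2-yl again therefore points toward a return to the numbers of compound 1 and compound 2, but phenethyl is not among the groups measured at this place, so no pair shows it directly. The expected step is a number 7.1 percentage points higher from compound 3 to compound 4 (within the scatter), modest and uncertain. Compound 4 is expected to give 11% in this assay, with a range from 0% to 26%.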

Compound 4, a percentage reported as inhibition, at one concentration (the size of the read-out at that concentration, not a potency): 20.1%
For compound 4 the middle estimate is 9.1 percentage points below the measured one; low and high end bracket the measured number.
By their numbers in this assay, from the lowest: compound 3; then compounds 1, 4 and 2 (each within the scatter of the next).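

In this assay, phenethyl in place of thiophen-2-yl on this aromatic carbon gives a number 16.2 percentage points higher from compound 3 to compound 4 (beyond the scatter) as its step, so the rise on leaving thiophen-2-yl is not limited to the 4-halophenyl groups. Against those groups the steps are a number 4.6 percentage points lower from compound 2 to compound 4 (within the scatter) and a number 5 percentage points higher from compound 1 to compound 4 (within the scatter) as printed, so phenethyl cannot be told apart from 4-fluorophenyl or 4-chlorophenyl here. Thiophen-2-yl is thus the only one of the four groups set apart, with steps beyond the scatter to each of the others.

From the compounds shown here alone, whether an amine or a carboxylic acid on the phenethyl ring, or a chain longer than phenethyl, would keep this level remains open. The four compounds vary at this place only and were read at one concentration, so nothing shows how the other groups on the shared core bear on it, and no measurement here explains the steps at this place.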